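The source may report more compounds than this note shows. Statements on the series, on what has been measured and on what is new or still open speak of the compounds shown alone.

Measured so far:
Compound 1 `Cc1cc(Nc2cc(N3CCN(C)CC3)nc(Nc3ccc(Cl)c(F)c3)n2)n[nH]1` gives 136 nM
Compound 2 `Cc1cc(Nc2cc(N3CCN(C)CC3)nc(Nc3ccc(F)c(Cl)c3)n2)n[nH]1` gives 80.9 nM

In a functional assay on A-431 cells (Homo sapiens) for antiproliferative activity, read by CCK-8 assay, with a stated time of 48 h (on this read-out lower numbers stand for stronger inhibition and higher numbers for weaker inhibition), compound 2 at 80.9 nM stands level with compound 1 within the scatter. Compound 3 `Cc1cc(Nc2cc(N3CCN(C)CC3)nc(Nc3ccc(F)c(F)c3)n2)n[nH]1` follows from compound 2 with fluoro in place of chloro on an aromatic carbon ortho to a fluoro group. Among the measured compounds shown here, the only measured step is a 1.7-fold lower number from compound 1 to compound 2 (0.23 log units; within the scatter) and it swaps the places of chloro and fluoro without removing chloro, so it is a loose guide. No step beyond the scatter is expected in this assay for this change. The estimated value for compound 3 is 120 nM within an expected range of 45 nM to 320 nM on present data. Thus a 1.5-fold higher number from compound 2 to compound 3 (0.17 log units; within the scatter) is the step expected.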

Compound 3, half-maximal inhibitory concentration: 177 nM
Compound 3: the middle estimate sits 1.5-fold (0.17 log units) below what was measured, and the stated range covers the measured number.
By their numbers in this assay, from the lowest: compounds 2, 1 and 3 (each within the scatter of the next, the first and the last beyond it).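

In this assay, among the compounds shown here, fluoro in place of chloro on 3-chloro-4-fluorophenyl gives a 2.2-fold higher number from compound 2 to compound 3 (0.34 log units; beyond the scatter) as the only step beyond the scatter, and a modest one. The same exchange on 4-chloro-3-fluorophenyl gives a 1.3-fold higher number from compound 1 to compound 3 (0.11 log units; within the scatter) and stays within the scatter, so on these numbers the two chloro placements do not respond alike. No available evidence bears on the reason for this difference.

Still open, going by these compounds, is how bromo, methyl or trifluoromethyl in place of the chloro of compound 2 would compare with chloro and fluoro.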